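This account rests on a few compounds, and the source may have more. Where it says the series, first, only, none or still open, it means among the compounds named here.

Four compounds are compared here, each carrying a urea or thiourea link to an aromatic ring that bears either trifluoromethyl or trifluoromethoxy. Compound 1 `CN1c2ccc(NC(=O)Nc3ccc(C(F)(F)F)cc3)cc2C(C)(C)C(=O)C1(C)C` and compound 2 `CN1c2ccc(NC(=O)Nc3ccc(OC(F)(F)F)cc3)cc2C(C)(C)C(=O)C1(C)C` share one core, while compound 3 `CN1c2ccc(NC(=S)Nc3ccc(C(F)(F)F)cc3)cc2C(C)(C)C(O)C1(C)C` and compound 4 `CN1c2ccc(NC(=S)Nc3ccc(OC(F)(F)F)cc3)cc2C(C)(C)C(O)C1(C)C` share another; the difference between the two cores is not broken down here.

In a functional assay on A2780 cells (Homo sapiens) for inhibition, with a stated time of 72 h (on this read-out lower numbers stand for stronger inhibition and higher numbers for weaker inhibition), compound 1 gives 2580 nM. Compound 2 differs from compound 1 in a single place: trifluoromethoxy in place of trifluoromethyl on an aromatic carbon. In this assay compound 2 gives 2400 nM, so that the change amounts to a 1.1-fold lower number from compound 1 to compound 2 (0.03 log units; within the scatter), and the two numbers cannot be told apart.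

Going by the values given here, compound 3, on the second core, gives in this assay 7600 nM, the highest of the three numbers measured so far, with both other compounds clearly lower. Among the compounds with values here, compound 4 differs from compound 3 by the same change as the one between compound 1 and compound 2: trifluoromethoxy in place of trifluoromethyl on an aromatic carbon. The surroundings of the change are described in the same words in both pairs, so this is the same change made on a different core.

Because a 1.1-fold lower number from compound 1 to compound 2 (0.03 log units; within the scatter) stayed within the scatter, the step from compound 3 to compound 4 is expected to be a 1.1-fold lower number from compound 3 to compound 4 (0.04 log units; within the scatter). Compound 4 is therefore estimated at about 7000 nM, most likely between 3500 nM and 14000 nM.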

Compound 4, half-maximal inhibitory concentration: 13100 nM
Compound 4: middle estimate off by 1.9-fold (0.27 log units), on the low side; the measured number falls inside the stated range.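

In this assay, putting trifluoromethoxy in place of trifluoromethyl on the second core gives a 1.7-fold higher number from compound 3 to compound 4 (0.24 log units; within the scatter), so here too the swap leaves the two numbers within the usual scatter of repeated measurements. Set beside the same swap on the first core, the result is no different from what repeat measurements alone could produce: the same change on two cores in this assay, a 1.1-fold lower number (0.03 log units; within the scatter) from compound 1 to compound 2 and a 1.7-fold higher number (0.24 log units; within the scatter) from compound 3 to compound 4, 1.9-fold (0.27 log units) apart, within the scatter of two such steps. On these two cores, then, the change carries over as a step too small to read, but two pairs are a thin base: they do not show that it would stay this small on other cores in the series, and they do not explain why the two groups behave alike in these cells.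

The compounds shown leave open whether a quite different group in the same place on the aromatic ring, such as an amine, a carboxylic acid or a longer alkyl chain, would move the number beyond the scatter. Going by these compounds alone, they also leave open how the urea or thiourea link and the rest of the two cores each contribute, since those features differ together and no pair here changes just one of them.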